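A New Side Chain on Compound 3

The compounds below may be only part of what the source reports. "The series", "measured", "known", "first", "only" and "open" are said of these compounds alone.

In a functional assay on PC-3 cells (Homo sapiens) for cytotoxicity, read by colorimetric assay and MTT assay (on this read-out lower numbers stand for stronger inhibition and higher numbers for weaker inhibition), compound 1 `COc1cc(OC)c2cc(-c3ccccc3)c(O)nc2c1` gives 10000 nM, compound 2 `COc1cc(OC)c2cc(-c3ccc(OCc4ccccc4)cc3)c(O)nc2c1` gives 10000 nM and compound 3 `CCN(CC)C(=O)Cn1c(=O)c(-c2ccc(OC)cc2)cc2c(OC)cc(OC)cc21` gives 10000 nM, so compound 3 stands level with the other two. Compound 4 `COc1ccc(-c2cc3c(OC)cc(OC)cc3n(CCC(=O)OCc3ccccc3)c2=O)cc1` carries (benzyloxycarbonyl)methyl in place of diethylcarbamoyl on a saturated chain carbon bound to an aromatic nitrogen. Going by the values given here, the only measured step, no change at the digits printed from compound 1 to compound 2 (within the scatter), put benzyloxy in place of hydrogen on an aromatic carbon, so it bears on this change only loosely. Among the compounds with values here, no measured step touches the place changed here. In this assay the expected step is therefore no change at the digits printed from compound 3 to compound 4 (within the scatter), nothing beyond the scatter. Compound 4 is estimated at 10000 nM, with an expected range from 3000 nM to 15000 nM.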

Compound 4, half-maximal inhibitory concentration: 10000 nM
Beside the measured number, compound 4's estimate shows no gap at the digits printed; the range from low to high includes it.
By their numbers in this assay, from the lowest: compounds 1, 2, 3 and 4 (each within the scatter of the next).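

In this assay, the only step shown at this place, (benzyloxycarbonyl)methyl in place of diethylcarbamoyl, gives no change at the digits printed from compound 3 to compound 4 (within the scatter). The entering group brings a six-membered aromatic ring of carbon only, yet the two compounds stay level, so this place now has a reading of its own, which the earlier step could not give. No available evidence bears on this result. As far as these compounds go, whether a carboxylic acid or an amine on this chain would shift the read-out away from the level of compound 4 at 10000 nM remains open.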